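The compounds below may be only part of what the source reports. "The series", "measured", "known", "first", "only" and "open" are said of these compounds alone.

Compound 1 `COC(=O)c1ccc(NCc2cncn2Cc2ccccc2N)cc1-c1ccccc1`: 25000 nM
Compound 2 `O=C(c1ccc(NCc2cncn2Cc2ccc(-c3ccccc3)cc2)cc1-c1ccccc1)N1CCCCC1`: > 1000 nM
Compound 3 `Nc1cc(-c2ccccc2)ccc1Cn1cncc1CNc1ccc(-c2nc3ccccc3s2)c(-c2ccccc2)c1`: > 1000 nM

All three compounds were run in a toxicity assay on NIH3T3 cells (Mus musculus) for cytotoxicity, read by resazurin assay; on this read-out higher numbers stand for an effect only at larger amounts of compound and lower numbers for an effect already at smaller amounts. For compound 2 the result is only a limit of the assay, > 1000 nM, and not a number. The same holds for compound 3, whose result is likewise a limit. Among the compounds with values here, compound 1 is the one compound with an actual number, 25000 nM. Within the data shown here, compound 2 therefore stands at the limit of > 1000 nM in this assay, at which 2 of the 3 values shown sit, and there is no measured step that connects it to either of the other two.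

Compound 4 `CN(C)c1ccc(NCc2cncn2Cc2ccc(-c3ccccc3)cc2)cc1-c1ccccc1` is the next compound to be measured. It differs from compound 2 in one place: dimethylamino in place of (piperidin-1-yl)carbonyl on an aromatic carbon. Among the measured compounds shown here, no pair of measured compounds differs in just this way, so the effect of this change has not been seen yet. In this assay, for the measured compounds named here, the expected step from compound 2 to compound 4 is none beyond the usual scatter, since the shared core is kept and the numbers known so far all sit in the weak range. The expected step is a step that the limit leaves unreadable from compound 2 to compound 4. Compound 4 is estimated at 20000 nM, with a range from 5000 nM to 60000 nM.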

Compound 4, half-maximal effective concentration: > 1000 nM
Compound 4 ended at the assay's limit; the forecaster's own chance of this, stated with the estimate: 50%; the middle value does not contradict the limit.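

Within the data shown here, compound 2 and compound 4 both end at a limit in this assay and not at a number, so no step between them can be read: the limit of > 1000 nM in this assay, at which 3 of the 4 values shown sit.

The compounds shown leave open whether dimethylamino in place of (piperidin-1-yl)carbonyl on an aromatic carbon changes the result in this assay at all, and if so in which direction and by how much.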